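The compounds below may be only part of what the source reports. "The series", "measured", "known", "first", "only" and "open" are said of these compounds alone.

Compounds measured in the growth assay:
- compound 1 `O=C(O)/C=C/c1ccncc1-c1ccc2cc[nH]c2c1`: > 10000 nM, a limit of the assay
- compound 2 `Cn1ccc2cc(-c3cnccc3/C=C/C(=O)O)ccc21`: > 10000 nM, a limit of the assay
- compound 3 `CNC(=O)CCc1ccncc1-c1ccc2ccccc2c1`: 8980 nM

All three were tested in a functional assay on MDA-MB-231 cells (Homo sapiens) for inhibition, read by sulforhodamine B assay, with a stated time of 72 h; on this read-out higher numbers stand for weaker inhibition of growth and lower numbers for stronger inhibition of growth. For compound 1 the result is a limit of the assay and not a number. For compound 2 the result is likewise a limit. Compound 3 is the only one of the three to return a number, and with 8980 nM it sits just under (the limit of > 10000 nM in this assay, at which 2 of the 3 values shown sit); it is therefore a weak inhibitor of growth, and nothing shown places it above or below the other two in any ordered way.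

Compound 4 `NNC(=O)CCc1ccncc1-c1ccc2ccccc2c1` differs from compound 3 in a single place: amino in place of methyl on an amide-type nitrogen. Among the compounds with values here, no step between two measured compounds is available, so the expectation for compound 4 rests on compound 3 alone and on the smallness of the change. The step of a 1.0-fold higher number from compound 3 to compound 4 (0.00 log units; within the scatter) is expected to be none beyond the scatter, in either direction. Compound 4 is accordingly estimated at 9000 nM, with a range from 3000 nM to 30000 nM, and there is a real chance that this assay returns only a limit for compound 4 rather than a number.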

Compound 4, concentration for 50% growth inhibition: > 10000 nM
Compound 4 ended at the assay's limit; the forecaster's own chance of this, stated with the estimate: 40%; middle value at least 1.1-fold (0.04 log units) away from the limit.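

In this assay compound 4 gives > 10000 nM, which is a limit of the assay and not a number. Read against that limit, the exchange of methyl for amino on the amide-type nitrogen gives an at least 1.1-fold higher number from compound 3 to compound 4 (0.04 log units; that floor lies within the scatter), so this step has only a floor and its true size cannot be read; what it does show is that this change at this position did not bring a lower number. With this result, a first single change at the amide-type nitrogen has been read, and compound 3 remains the only compound shown to return a number: the limit of > 10000 nM in this assay, at which 3 of the 4 values shown sit.

The compounds shown leave open whether a different group on that amide-type nitrogen, such as a hydroxyl group, an ethyl group or a longer chain, would give a clear number in this assay and move it away from the limit. They also leave open how far past the limit compound 4 lies, and whether a dimethylamino group in place of the amino group would return a number at all.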